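The compounds below may be only part of what the source reports. "The series", "measured", "known", "first", "only" and "open" are said of these compounds alone.

Measured in an ADME assay on MT4 cells (Homo sapiens) for cytotoxicity, read by MTT assay; on this read-out higher numbers stand for lower toxicity in this test and lower numbers for higher toxicity in this test:
compound 1 `Cc1ccc(N(C(=O)c2cccc([N+](=O)[O-])c2)C(=S)OCCN2C(=O)c3ccccc3C2=O)cc1`: 100000 nM
compound 2 `Cc1ccc(N(C(=O)c2ccc(F)cc2F)C(=S)OCCN2C(=O)c3ccccc3C2=O)cc1`: 20000 nM

Within the data shown here, compound 2, at 20000 nM, holds the lower of the two numbers so far. The next compound is compound 3 `Cc1ccc(N(C(=O)c2ccc(Cl)cc2Cl)C(=S)OCCN2C(=O)c3ccccc3C2=O)cc1`, with 2,4-dichlorophenyl in place of 2,4-difluorophenyl on a carbonyl carbon. Among the measured compounds shown here, one measured step bears on this change, at the same place: a 5.0-fold lower number from compound 1 to compound 2 (0.70 log units; beyond the scatter). That modest step shows that exchanging the group on this carbonyl carbon can move the number in this assay. It involves a different pair of groups, however, and the data give no direction for the present exchange. No step beyond the scatter is therefore expected, with only a slight lean towards a lower number. The expected step is a 1.3-fold lower number from compound 2 to compound 3 (0.12 log units; within the scatter). For compound 3 the estimated value is 15000 nM, with an expected range from 5000 nM to 50000 nM.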

Compound 3, half-maximal cytotoxic concentration: 49000 nM
Compound 3: the middle estimate sits 3.3-fold (0.51 log units) below what was measured; low and high end bracket the measured number.
By their numbers in this assay, from the lowest: compound 2; then compound 3; then compound 1.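

In this assay, with the phenyl ring kept and only its halogen exchanged, 2,4-dichlorophenyl in place of 2,4-difluorophenyl on a carbonyl carbon gives a 2.5-fold higher number from compound 2 to compound 3 (0.39 log units; beyond the scatter), so the number at this position depends on which halogen the ring carries and not only on the change away from 3-nitrophenyl. Against 3-nitrophenyl, the new group gives a 2.0-fold lower number from compound 1 to compound 3 (0.31 log units; beyond the scatter), which places compound 3 between compound 2 and compound 1 and leaves both halogenated compounds with lower numbers than compound 1. The data shown offer no measurement that accounts for this order.

Open, from the compounds shown here alone, is how an unsubstituted phenyl, a 2,4-dimethylphenyl or an aminophenyl on this carbonyl carbon would compare with these three groups. Also open, going by these compounds, is whether the same order of groups would hold on a core other than the shared one.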